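A few compounds are considered here, and "the series" means these few. Any claim that something is new, unique, unknown or untested is made for them only; others in the source may bear on it.

Measured so far:
compound 1 `CCC/N=C1\S/C(=C\c2ccc(O)cn2)C(=O)N1c1ccccc1C` gives 3
compound 2 `CCC/N=C1\S/C(=C\c2ccc(O)c(C(C)C)c2)C(=O)N1c1ccccc1C` gives 4.3
compound 3 `CCC/N=C1\S/C(=C\c2ccc(O)c(Br)c2)C(=O)N1c1ccccc1C` gives 3.9

In a physicochemical assay for lipophilicity, read by HPLC, at pH 7.4 (on this read-out lower numbers stand for lower lipophilicity and higher numbers for higher lipophilicity), compound 3 (3.9) stands second highest of the three. Compound 4 `CCC/N=C1\S/C(=C\c2ccc(O)c(C)c2)C(=O)N1c1ccccc1C` has not been measured and carries one change: methyl in place of bromo on an aromatic carbon, ortho to a hydroxy group (methyl in place of bromo on an aromatic carbon). The closest evidence is a modest step (a number 0.40 log units lower from compound 2 to compound 3 (beyond the scatter)), bromo in place of isopropyl on an aromatic carbon. The larger step (a number 0.90 log units higher from compound 1 to compound 3 (beyond the scatter)) replaces a whole aromatic group, so it bears on this change only loosely. Among the compounds with values here, no measured compound carries this methyl, so the direction remains uncertain. A small downward step, probably within the scatter, is expected (a number 0.20 log units lower from compound 3 to compound 4 (within the scatter)). For compound 4 the estimated value is 3.7 (expected range 3.3 to 4.1).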

Compound 4, distribution coefficient: 3.8
Estimate against measurement, compound 4: 0.10 log units below, within the range that was stated.
By their numbers in this assay, from the lowest: compound 1; then compounds 4 and 3 (each within the scatter of the next); then compound 2.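

In this assay, methyl and bromo on an aromatic carbon ortho to a hydroxy group cannot be told apart (a number 0.10 log units lower from compound 3 to compound 4 (within the scatter)). Isopropyl at the same place does stand apart, and methyl in its place gives a clear step (a number 0.50 log units lower from compound 2 to compound 4 (beyond the scatter)). The 4-hydroxy-3-methylphenyl group also stands clearly apart from 5-hydroxypyridin-2-yl (a number 0.80 log units higher from compound 1 to compound 4 (beyond the scatter)). As far as these compounds go, what an amine, a carboxylic acid or a longer chain would do at this place stays open. No measurement at hand gives a cause for any of these steps.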